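From 3-chlorophenyl to 3-bromo-4-fluorophenyl on the amide-type nitrogen

This account rests on a few compounds, and the source may have more. Where it says the series, first, only, none or still open, it means among the compounds named here.

Of the compounds shown here, three sharing one core have been measured in a functional assay on A549 cells (Homo sapiens) for inhibition, read by MTT assay, with a stated time of 72 h; a lower number here means a stronger inhibitor, a higher number a weaker inhibitor. Compound 1 (`CCCc1ccc(NC(=O)C2CCN(C/C=C/c3ccccc3)CC2)cc1`) gives 9470 nM, compound 2 (`O=C(Nc1cccc(F)c1)C1CCN(C/C=C/c2ccccc2)CC1`) gives 43300 nM, and compound 3 (`O=C(Nc1cccc(Cl)c1)C1CCN(C/C=C/c2ccccc2)CC1`) gives 19100 nM. Two steps fix the standing of the chloro member: a 2.0-fold higher number from compound 1 to compound 3 (0.30 log units; within the scatter), and a 2.3-fold lower number from compound 2 to compound 3 (0.36 log units; beyond the scatter). Compound 3 therefore cannot be separated from compound 1, while its number lies under that of compound 2.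

Compound 4 (`O=C(Nc1ccc(F)c(Br)c1)C1CCN(C/C=C/c2ccccc2)CC1`) has not yet been measured in this assay. It carries 3-bromo-4-fluorophenyl in place of 3-chlorophenyl on an amide-type nitrogen. The nearest evidence is the modest halogen swap, chloro in place of fluoro on an aromatic carbon, which gave a 2.3-fold lower number from compound 2 to compound 3 (0.36 log units; beyond the scatter). Among the measured compounds shown here, the largest change seen on this aryl group is a 4.6-fold higher number from compound 1 to compound 2 (0.66 log units; beyond the scatter), which shows how far such a replacement has moved the number so far. For the measured compounds named here, no measured compound carries bromo or two halogens on this ring, so the data offer no direct reading. The expected change is small, and the estimate is a 1.3-fold lower number from compound 3 to compound 4 (0.10 log units; within the scatter), not expected to pass beyond the scatter. For compound 4 the estimated value is 15000 nM, with an expected range of 6000 nM to 38000 nM.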

Compound 4, half-maximal inhibitory concentration: 11700 nM
Estimate against measurement, compound 4: 1.3-fold (0.11 log units) above; low and high end bracket the measured number.
By their numbers in this assay, from the lowest: compounds 1, 4 and 3 (each within the scatter of the next); then compound 2.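

In this assay, 3-bromo-4-fluorophenyl in place of 3-chlorophenyl gives a 1.6-fold lower number from compound 3 to compound 4 (0.21 log units; within the scatter), and 3-bromo-4-fluorophenyl in place of 4-propylphenyl gives a 1.2-fold higher number from compound 1 to compound 4 (0.09 log units; within the scatter), so compound 4 cannot be separated from either compound 3 or compound 1. Among the compounds shown here, only the step from the 3-fluorophenyl member is clear, at a 3.7-fold lower number from compound 2 to compound 4 (0.57 log units; beyond the scatter), which leaves compound 2 with the highest number of the four, apart from the other three, and shows that this position accepts a ring bearing bromo and fluoro together without any loss against the chloro or propyl members. Nothing available on these compounds accounts for these numbers.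

As far as these compounds go, compound 4 changes bromo and fluoro together, so the share of each in its step from compound 2 stays open. From the compounds shown here alone, it also stays open whether an amine, a carboxylic acid or a chain longer than propyl on this aryl group would give a number beyond the scatter of compound 1.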